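Solubility notes: from compound 2 to compound 3

This account rests on a few compounds, and the source may have more. Where it says the series, first, only, none or still open, it means among the compounds named here.

Measured in a physicochemical assay for solubility, in phosphate buffer, at pH 7.4; a lower number here means a less soluble compound, a higher number a more soluble compound:
- Compound 1 `CC(=O)N[C@@H]1CCC[C@H](C(=O)Nc2cc(-c3cnc(C)n3C)c(Cl)cn2)C1`: > 1000000 nM (a limit)
- Compound 2 `CC(=O)N[C@@H]1CCC[C@H](C(=O)Nc2cc(-c3cnc4n3CCC4)c(Cl)cn2)C1`: 490000 nM

Among the measured compounds shown here, compound 2, at 490000 nM, holds the only actual number in this small series. Compound 1 stands at > 1000000 nM, which is a limit and not a number.

Compound 3 `CC(=O)N[C@@H]1CCC[C@H](C(=O)Nc2cc(-c3cnn4c3COCC4)c(Cl)cn2)C1` has not yet been measured. The change from compound 2 is a group of 9 heavy atoms (6 carbon, 2 nitrogen, 1 oxygen; one five-membered aromatic ring with 2 hetero atoms, one six-membered non-aromatic ring with 2 hetero atoms) in place of a group of 8 heavy atoms (6 carbon, 2 nitrogen; one five-membered non-aromatic ring with 1 hetero atom, one five-membered aromatic ring with 2 hetero atoms), on an aromatic carbon, ortho to a chloro group and opposite the ring nitrogen.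

For the measured compounds named here, only one measured step bears on this change: an at least 2.0-fold lower number from compound 1 to compound 2 (0.30 log units; that floor lies within the scatter). That step also replaces the group at this same place, but it gives only a floor, and no exact size. Going by the values given here, with an at least 2.0-fold lower number from compound 1 to compound 2 (0.30 log units; that floor lies within the scatter) as the sole guide, no step beyond the scatter is expected in this assay, and no direction can be favoured with confidence. The expected step is a 1.2-fold lower number from compound 2 to compound 3 (0.09 log units; within the scatter). For compound 3 the estimated value is 400000 nM, with an expected range from 130000 nM to 1000000 nM.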

Compound 3, solubility: 220000 nM
The estimate for compound 3 lay 1.8-fold (0.26 log units) above the measured number; low and high end bracket the measured number.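

In this assay the position on the aromatic carbon opposite the ring nitrogen now gives its first step of exact size, a 2.2-fold lower number from compound 2 to compound 3 (0.35 log units; beyond the scatter), as the group with a six-membered non-aromatic ring with 2 hetero atoms enters in place of the group with a five-membered non-aromatic ring with 1 hetero atom. The earlier comparison offered only a floor within the scatter, whereas the series now holds a step beyond the scatter at this place, an at least 4.5-fold lower number from compound 1 to compound 3 (0.65 log units; beyond the scatter), so the number in this assay does respond to the group here. From the compounds shown here alone, that second step is also a floor and its true size stays unknown, because compound 1 stands at a limit and not at a number: the limit of > 1000000 nM in this assay, at which 1 of the 3 values shown sits.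

Compound 3 differs from compound 2 in ring size, in the oxygen atom and in the ring carrying the hetero atoms, all in one step, and the compounds shown do not separate these parts. Going by these compounds, how an amine or a carboxylic acid on the non-aromatic ring of this group would read in this assay also remains open.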